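From difluoromethyl to bromo on the aromatic ring

The source may hold more compounds than are shown below. What is called first, only, known or untested is meant among the compounds shown, and "the series" means these compounds.

- Compound 1 `NS(=O)(=O)CC(=O)NCCSc1nonc1/C(=N/O)Nc1cccc(C(F)F)c1`: > 3 h (a limit)
- Compound 2 `NS(=O)(=O)CC(=O)NCCSc1nonc1/C(=N/O)Nc1ccc(F)c(C(F)F)c1`: 2.77 h
- Compound 3 `NS(=O)(=O)CC(=O)NCCSc1nonc1/C(=N/O)Nc1ccc(F)c(Br)c1`: not yet measured

Within the data shown here, in an ADME assay on microsomes from liver (Homo sapiens) for metabolic stability (a lower number here means that the compound disappears faster, a higher number that the compound lasts longer), compound 2 gives 2.77 h, the only exact number so far. Compound 1 gives only a limit: the limit of > 3 h in this assay, at which 1 of the 2 values shown sits.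

Compound 3 carries bromo in place of the difluoromethyl of compound 2 (bromo in place of difluoromethyl on an aromatic carbon). Among the measured compounds shown here, the one measured step, an at least 1.0-fold lower number from compound 1 to compound 2 (0.03 log units; that floor lies within the scatter), is a different change, fluoro in place of hydrogen, so it offers only a loose guide. No change beyond the scatter is therefore expected in this assay. The expected step is a 1.1-fold lower number from compound 2 to compound 3 (0.03 log units; within the scatter). Compound 3 is expected to show a half-life near 2.6 h, with an estimated range of 1.4 h to 3.5 h.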

Compound 3, half-life: 2.37 h
Compound 3: middle estimate off by 1.1-fold (0.04 log units), on the high side; measured number inside the range.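

At this position, ortho to a fluoro group, bromo takes the place of difluoromethyl with no shift beyond the scatter in this assay (a 1.2-fold lower number from compound 2 to compound 3 (0.07 log units; within the scatter)). One heavy atom thus stands in for three here without a clear loss of half-life, and the wider swap of the whole aromatic group also stays within the scatter at its floor (an at least 1.2-fold lower number from compound 1 to compound 3 (0.10 log units; that floor lies within the scatter)). Compound 1 is a limit, not a number: the limit of > 3 h in this assay, at which 1 of the 3 values shown sits. Still open, as far as these compounds go, is whether an amine, a methoxy group or a nitrile at this position would give a similar half-life.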